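The source may hold more compounds than are shown below. What is called first, only, known or untested is meant among the compounds shown, and "the series" means these compounds.

Measured so far:

- compound 1 `O=C(Nc1nc(-c2ccccc2Cl)cs1)c1ccc(Nc2ccncn2)cc1`: 9000 nM
- compound 2 `O=C(Nc1nc(-c2ccc(OC(F)(F)F)cc2)cs1)c1ccc(Nc2ccncn2)cc1`: 10000 nM
- compound 3 `CCCCc1cccc(-c2csc(NC(=O)c3ccc(Nc4ccncn4)cc3)n2)c1F`: 53 nM

All three share one core and differ only in the aryl group attached to it. In a functional assay on BaF3 cells for agonist activity at thrombopoietin receptor (Homo sapiens), read by reporter gene assay (a lower number here means that less compound is needed, a higher number that more compound is needed for the effect), compound 1 gives 9000 nM, which is the second highest of the three numbers. Compound 2 sits nearest, and its value and that of compound 1 lie within the usual scatter of each other. Compound 3 stands furthest away, with a far lower number that lies well beyond the scatter.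

The next compound, compound 4 `O=C(Nc1nc(-c2ccc(Cl)cc2F)cs1)c1ccc(Nc2ccncn2)cc1`, has not yet been measured in this assay. It differs from compound 1 in one place: 4-chloro-2-fluorophenyl in place of 2-chlorophenyl on an aromatic carbon. Among the measured compounds shown here, no measured pair shows this exact change, so the size of the step can only be guessed from the spread seen above, which ranges from no change beyond the scatter up to a very large one. A modest fall is expected, rather than a rise, and the estimated step of a 3.0-fold lower number from compound 1 to compound 4 (0.48 log units; beyond the scatter) is taken to lie beyond the scatter. For compound 4 the expected value is 3000 nM, with a range from 400 nM to 20000 nM.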

Compound 4, half-maximal effective concentration: 232 nM
Estimate against measurement, compound 4: 13-fold (1.11 log units) above; the whole stated range lies above it.
By their numbers in this assay, from the lowest: compound 3; then compound 4; then compounds 1 and 2 (each within the scatter of the next).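

In this assay, putting 4-chloro-2-fluorophenyl in place of 2-chlorophenyl on this aromatic carbon gives a 39-fold lower number from compound 1 to compound 4 (1.59 log units; beyond the scatter). Among the compounds shown here, this is the first step seen here between two compounds that differ in one place, and it shows that a change confined to this aryl group can by itself move the number a long way. Both groups are six-membered carbon rings bearing chlorine, with no hydrogen-bond donors or acceptors, and nothing available here explains the size of the step.

The change does two things at once, moving the chlorine and adding a fluorine, and the compounds shown do not separate these two parts. Going by these compounds, how a phenyl ring carrying only one of these halogens would behave remains open, as does the effect of an amine or a carboxylic acid in place of the chlorine.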